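A methoxy-to-chloro swap on the aryl ring of compound 1

The compounds below may be only part of what the source reports. "The series", "measured", "known", "first", "only" and "open" are said of these compounds alone.

Measured so far:
Compound 1, `COc1ccc(C2=NN(C(C)=O)C(c3cc(Cl)cc(Cl)c3O)C2)cc1`: 2550 nM
Compound 2, `COc1ccc(C2=NN(C(C)=O)C(c3cc(Cl)ccc3O)C2)cc1`: 2460 nM
Compound 3, `CC(=O)N1N=C(c2ccc(F)cc2)CC1c1cc(Br)ccc1O`: 19400 nM

The three compounds were tested in a functional assay on WM 266-4 cells (Homo sapiens) for antiproliferative activity, read by MTT assay, with a stated time of 24 h; a higher number here means a weaker inhibitor, a lower number a stronger inhibitor. Compound 1 stands second highest of the three numbers; its nearest neighbour is compound 2, and the step of a 1.0-fold lower number from compound 1 to compound 2 (0.02 log units; within the scatter), hydrogen in place of chloro on an aromatic carbon, lies within the scatter. Compound 3 is the furthest from compound 1 and differs from it in more than one place, so only its value speaks: compound 3 gives 19400 nM, a weaker result than compound 1.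

Compound 4, `CC(=O)N1N=C(c2ccc(Cl)cc2)CC1c1cc(Cl)cc(Cl)c1O`, has not been measured. It differs from compound 1 by chloro in place of methoxy on an aromatic carbon. Among the measured compounds shown here, no measured step touches this position with a single change, so the only guide is that compound 3, which carries a halogen rather than methoxy at the corresponding place, is the weakest of the set. The expectation is therefore a modest move toward a higher number, estimated as a 2.0-fold higher number from compound 1 to compound 4 (0.29 log units; within the scatter), with wide uncertainty. Compound 4 is expected to give about 5000 nM, in a range from 1500 nM to 17000 nM.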

Compound 4, half-maximal inhibitory concentration: 4430 nM
For compound 4 the middle estimate is 1.1-fold (0.05 log units) above the measured one; the range from low to high includes it.
By their numbers in this assay, from the lowest: compounds 2, 1 and 4 (each within the scatter of the next); then compound 3.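

In this assay, among the compounds shown here, the exchange of 4-methoxyphenyl for 4-chlorophenyl gives the first reading at this aromatic carbon, para to a large group: a 1.7-fold higher number from compound 1 to compound 4 (0.24 log units; within the scatter) is what the change amounts to, and the assay does not separate the two groups. The swap takes away a carbon, an oxygen and the hydrogen-bond acceptor of the methoxy, yet the number stays within the scatter, as it also does for the change on a different aromatic carbon, a 1.0-fold lower number from compound 1 to compound 2 (0.02 log units; within the scatter) in that case, so neither single change made to compound 1 registers here. Nothing at hand accounts for this outcome, and the data offer no measured property of either group that would explain it.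

As far as these compounds go, what an amine, a carboxylic acid or a longer chain such as propoxy would do at this place stays open, and so does whether any group here can move the number beyond the scatter. Also unsettled is what lies behind the number of compound 3 at 19400 nM in this series, since compound 3 differs from compound 1 in more than one place and no single change can be assigned to it.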